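The compounds below may be only part of what the source reports. "The series", "measured", "known", "first", "only" and "open" are said of these compounds alone.

Three compounds that share a basic amine-bearing ring attached to a bicyclic core have been measured in an assay for binding affinity to 5-hydroxytryptamine receptor 1B (Homo sapiens), read by radioligand binding; on this read-out higher numbers stand for weaker inhibition and lower numbers for stronger inhibition. Compound 1, `CN1CCC(c2c[nH]c3cnc(NC(=O)c4ccc(F)cc4)cc23)CC1`, gives 80 nM in this assay. Compound 2, `CN1CCC(c2c[nH]c3ccc(NC(=O)c4cccc(F)c4)nc23)CC1`, gives 1600 nM, and compound 3, `CC(=O)Nc1ncc2[nH]cc(C3CCN(C)CC3)c2n1`, gives 2900 nM. Among these three numbers compound 2 stands second highest: the values of compound 2 and compound 3 lie within the usual scatter of each other, so no order can be claimed between them, whereas the gap between compound 2 and compound 1 is well beyond the scatter, with compound 1 showing the far lower, and therefore stronger, number.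

Compound 4, `CN1CCC(c2c[nH]c3ccc(NC(=O)Nc4ccc(F)cc4)nc23)CC1`, is the next compound to be measured. It differs from compound 2 in one place: (4-fluorophenyl)amino in place of 3-fluorophenyl on a carbonyl carbon. Within the data shown here, no pair among the measured compounds isolates this particular change, so nothing measured here tells directly how large its effect should be. The expectation is a modest move in this assay toward a lower number, estimated as the step of a 2.0-fold lower number from compound 2 to compound 4 (0.30 log units; within the scatter), but one that may well fall inside the scatter. Compound 4 is accordingly expected to give about 800 nM, with a likely range from 150 nM to 4000 nM.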

Compound 4, inhibition constant: 3.2 nM
Estimate against measurement, compound 4: 250-fold (2.40 log units) above, and the stated range ends above it.
By their numbers in this assay, from the lowest: compound 4; then compound 1; then compounds 2 and 3 (each within the scatter of the next).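

In this assay, among these compounds, the group on this carbonyl carbon proves to be a powerful control on the number: replacing 3-fluorophenyl with (4-fluorophenyl)amino gives a 500-fold lower number from compound 2 to compound 4 (2.70 log units; beyond the scatter) and marks the first pair here that differs in one place, so the size of such a change can now be read directly. The swap nevertheless combines two differences, since the entering group adds an amino nitrogen with its hydrogen-bond donor and also carries its fluorine as 4-fluoro rather than 3-fluoro. Nothing available here explains the size of this step.

The compounds shown therefore leave open how much of the step belongs to the added nitrogen and how much to the fluorine, a question that (3-fluorophenyl)amino and 4-fluorophenyl on the same carbonyl carbon of the core of compound 2 could help to separate. They also leave open whether the fluorine is needed at all, which an unsubstituted phenylamino group at this place would address, and whether the step carries over to the other cores shown.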